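Pyridyl isomer swap in a low-toxicity series

The source may report more compounds than this note shows. Statements on the series, on what has been measured and on what is new or still open speak of the compounds shown alone.

Compound 1 `Cc1nc(-c2cccnc2)sc1-c1nnc(-c2ccc(Cl)cc2)o1` and compound 2 `Cc1nc(-c2cccnc2)sc1-c1nnc(-c2ccncc2)o1` share one core. In an ADME assay on THP-1 cells (Homo sapiens) for cytotoxicity, read by MTT assay (on this read-out higher numbers stand for lower toxicity in this test and lower numbers for higher toxicity in this test), compound 1 gives only a limit, > 100 ug/mL. Compound 2 likewise gives only a limit, > 100 ug/mL. From the compounds shown here alone, the step from compound 1 to compound 2 is a step that the two limits leave unreadable from compound 1 to compound 2, so its size stays unknown, both values sitting at the limit of > 100 ug/mL in this assay, at which 2 of the 2 values shown sit. Compound 3 `Cc1nc(-c2cccnc2)sc1-c1nnc(-c2cccnc2)o1` differs from compound 2 by pyridin-3-yl in place of pyridin-4-yl on an aromatic carbon. For the measured compounds named here, no measured step gives a readable size, so for compound 3 the expected step is a step that the limit leaves unreadable from compound 2 to compound 3, none beyond the scatter. Compound 3 is therefore expected at 150 ug/mL, within 60 ug/mL to 400 ug/mL, most likely again as a limit.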

Compound 3, half-maximal cytotoxic concentration: > 100 ug/mL
Compound 3: a limit, no number (the forecaster's own chance of this, stated with the estimate: 85%); the middle value does not contradict the limit.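

No step among compound 1, compound 2 and compound 3 can be read, because all three sit at one limit: the limit of > 100 ug/mL in this assay, at which 3 of the 3 values shown sit.

From the compounds shown here alone, whether 4-chlorophenyl, pyridin-4-yl and pyridin-3-yl differ at all in this assay stays open.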